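The source may hold more compounds than are shown below. What is called first, only, known or untested is meant among the compounds shown, and "the series" means these compounds.

Measured in a functional assay on the whole organism (strain Wistar) for inhibition, with Rattus norvegicus as the target, read by paw edema, with stated times of 30 min and 120 min, at a dose of 50 mg/kg by the oral route; a lower number here means less inhibition, a higher number more inhibition at the dose given (going by the name of the read-out):

compound 1 `Cc1ccc(C2=NN(c3ccc([N+](=O)[O-])cc3)C(c3cn(-c4ccccc4)nc3-c3ccc(Cl)c(Cl)c3)C2)cc1`: 71.9%
compound 2 `O=CN1N=C(c2ccc(F)cc2)CC1c1cn(-c2ccccc2)nc1-c1ccc(Cl)c(Cl)c1`: 60.9%
compound 3 `CC(=O)N1N=C(c2ccc(Cl)cc2)CC1c1cn(-c2ccccc2)nc1-c1ccc(Cl)c(Cl)c1`: 66.4%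

Compound 2 stands at the lowest of the three numbers. Its nearest neighbour is compound 3, whose value lies within the usual scatter of that of compound 2, so the two cannot be ordered. Compound 1 gives a number higher than compound 2 by a margin beyond the scatter.

Compound 4 `Fc1ccc(C2=NNC(c3cn(-c4ccccc4)nc3-c3ccc(Cl)c(Cl)c3)C2)cc1` is not yet measured in this assay. It differs from compound 2 in one place: hydrogen in place of formyl on an amine nitrogen in a ring. The formyl that leaves takes two heavy atoms and one hydrogen-bond acceptor with it; a hydrogen enters on the amine nitrogen in the ring.

For the measured compounds named here, no measured pair shows the effect of such a change, and all three measured compounds carry a substituent on that ring nitrogen, so nothing here fixes the size of the step. The expected step is small, a number 5.9 percentage points lower from compound 2 to compound 4 (within the scatter), at most a slight drop and likely within the scatter. Compound 4 is estimated to give 55%, expected between 40% and 70%.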

Compound 4, a percentage reported as inhibition, in the whole organism at one dose (the size of the read-out at that dose, not a potency): 46.1%
Beside the measured number, compound 4's estimate is 8.9 percentage points above it, within the range that was stated.
By their numbers in this assay, from the lowest: compound 4; then compounds 2, 3 and 1 (each within the scatter of the next, the first and the last beyond it).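

For the compounds shown here, replacing formyl with hydrogen on the amine nitrogen in the ring gives, in this assay, a number 14.8 percentage points lower from compound 2 to compound 4 (beyond the scatter), the first readable step at this position. The position is therefore not indifferent to what it carries: with the 4-fluorophenyl group and the rest of the core held constant, the presence of the formyl goes with more inhibition at the dose given. Nothing measured on these compounds accounts for the size or direction of this step.

This single pair leaves open whether the step holds with another aryl group on the ring, and whether it depends on the carbonyl or only on having some substituent on that nitrogen. A methyl on the ring nitrogen, with the 4-fluorophenyl group kept, would separate these two readings.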